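The source may report more compounds than this note shows. Statements on the series, on what has been measured and on what is new or still open speak of the compounds shown alone.

Compound 1 `CCCOC(=O)c1ccc(CN)cc1`: 500000000 nM
Compound 2 `NCc1ccc(C(=O)OCCCc2ccccc2)cc1`: 500000000 nM

In an assay on isolated protein for inhibition of serine protease 1 (Homo sapiens) (a higher number here means a weaker inhibitor, a lower number a stronger inhibitor), compound 1 gives 500000000 nM. In this assay compound 2 gives 500000000 nM, so compound 1 stands level with compound 2 at the digits shown, and the step of no change at the digits printed from compound 1 to compound 2 (within the scatter) lies within the usual scatter. Compound 3 `NCc1ccc(C(=O)OCc2ccccc2)cc1` differs from compound 1 by phenyl in place of ethyl on a saturated chain carbon bound to an oxygen next to a carbonyl group. Within the data shown here, only one measured step bears on this change: no change at the digits printed from compound 1 to compound 2 (within the scatter), which likewise brings a phenyl into the same side of the shared core and left the number unchanged. With nothing in the measured steps pointing either way, no change beyond the scatter is expected in this assay for compound 3, that is, a step of no change at the digits printed from compound 1 to compound 3 (within the scatter) is expected. Compound 3 is therefore estimated at 500000000 nM, with a range from 100000000 nM to 500000000 nM.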

Compound 3, inhibition constant: 30000000 nM
For compound 3 the middle estimate is 17-fold (1.22 log units) above the measured one, outside the stated range (below it).
By their numbers in this assay, from the lowest: compound 3; then compounds 1 and 2 (each within the scatter of the next).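

In this assay phenyl in place of ethyl on a saturated chain carbon bound to an oxygen next to a carbonyl group brings a 17-fold lower number from compound 1 to compound 3 (1.22 log units; beyond the scatter) and so shows that the number on this side of the shared core can move. The earlier pair gave no sign of this: with phenyl three bonds along the chain from that oxygen, the result was no change at the digits printed from compound 1 to compound 2 (within the scatter) and so where the phenyl stands matters in these compounds. No measurement shown here explains why the phenyl counts at one place and not at the other.

The compounds shown leave open whether it is the ring itself that matters at this place, as a cyclohexyl group there would test. They also leave open whether an amine or a carboxylic acid on the phenyl would shift the number further.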